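Taking the hydroxy group off compound 3

The source may report more compounds than this note shows. Statements on the series, on what has been measured and on what is new or still open speak of the compounds shown alone.

In an ADME assay on HeLa Rh cells (Homo sapiens) for cytotoxicity, read by microscopy (on this read-out higher numbers stand for lower toxicity in this test and lower numbers for higher toxicity in this test), compound 3 `COc1cc(CC(O)c2ccc(-c3ccc(CO)cc3)cc2)c([N+](=O)[O-])cc1OC` gives > 244000 nM, which is a limit and not a number. Compound 1 `COc1cc(CC(O)c2ccc(-c3ccc(C#N)cc3)cc2)c([N+](=O)[O-])cc1OC` gives 4700 nM and compound 2 `COc1cc(CC(O)c2ccc(-c3ccc([N+](=O)[O-])cc3)cc2)c([N+](=O)[O-])cc1OC` gives 21000 nM, which puts compound 3 at the least toxic end of the three. Compound 4 `COc1cc(CC(O)c2ccc(-c3ccc(C)cc3)cc2)c([N+](=O)[O-])cc1OC` differs from compound 3 by hydrogen in place of hydroxy on a saturated chain carbon bound to an aromatic carbon: hydrogen in place of hydroxy, so hydroxymethyl becomes methyl. The closest evidence comes from two large steps that bring in hydroxymethyl, an at least 51-fold higher number from compound 1 to compound 3 (1.71 log units; beyond the scatter) and an at least 11-fold higher number from compound 2 to compound 3 (1.06 log units; beyond the scatter), while a 4.5-fold higher number from compound 1 to compound 2 (0.65 log units; beyond the scatter) is only modest. Without hydroxymethyl, a reading nearer those of compound 1 and compound 2 seems likely. The expected change is a clear drop, an at least 8.1-fold lower number from compound 3 to compound 4 (0.91 log units; beyond the scatter). For compound 4 the estimated value is 30000 nM, with an expected range of 6000 nM to 150000 nM.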

Compound 4, half-maximal cytotoxic concentration: 4700 nM
The estimate for compound 4 lay 6.4-fold (0.81 log units) above the measured number; the whole stated range lies above it.
By their numbers in this assay, from the lowest: compounds 1 and 4 (each within the scatter of the next); then compound 2. At a limit, above all of these: compound 3.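

In this assay, hydrogen in place of hydroxy gives an at least 51-fold lower number from compound 3 to compound 4 (1.71 log units; beyond the scatter), so this one oxygen on the saturated chain carbon accounts for the whole gap. For compound 3 the reading is a limit and not a number: the limit of > 244000 nM in this assay, at which 1 of the 4 values shown sits. Methyl reads like cyano, with no change at the digits printed from compound 1 to compound 4 (within the scatter), and also falls short of nitro, with a 4.5-fold lower number from compound 2 to compound 4 (0.65 log units; beyond the scatter), so among these four compounds only hydroxymethyl stands far apart. As far as these compounds go, whether the free hydroxy group itself is needed stays open. How an amine, a carboxylic acid or methoxymethyl would read in its place is also unknown.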